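Phenyl to ethyl on the carbamoyl chain, acid ceramidase

The source may report more compounds than this note shows. Statements on the series, on what has been measured and on what is new or still open speak of the compounds shown alone.

Compound 1 `O=C(NCCCCc1ccccc1)n1nnc2ccccc21` and compound 2 `O=C(NCCCCc1ccccc1)n1cnc2ccccc21` carry the same chain on different cores; the difference between the two cores is not broken down here. In an assay on HEK293 cells for inhibition of acid ceramidase (Homo sapiens), read by fluorescence, with stated times of 30 min and 1 h (a lower number here means a stronger inhibitor, a higher number a weaker inhibitor), compound 1 gives 2.1 nM and compound 2 gives 2.5 nM, two numbers within the scatter of each other. Compound 3 `CCCCCCNC(=O)n1cnc2ccccc21` keeps the core of compound 2 with ethyl in place of phenyl on a saturated chain carbon, four bonds along the chain from an amide-type nitrogen, and in this assay compound 3 gives 6.6 nM, a step of a 2.6-fold higher number from compound 2 to compound 3 (0.42 log units; beyond the scatter). Compound 4 `CCCCCCNC(=O)n1nnc2ccccc21` keeps the core of compound 1 with the same change, (ethyl in place of phenyl on a saturated chain carbon, four bonds along the chain from an amide-type nitrogen), at a place described in the same words. Among the compounds with values here, the expected step is a 2.6-fold higher number from compound 1 to compound 4 (0.42 log units; beyond the scatter), resting on a 2.6-fold higher number from compound 2 to compound 3 (0.42 log units; beyond the scatter) as the only measured instance of this change. Compound 4 is expected to give 5.5 nM, between 3 nM and 11 nM.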

Compound 4, half-maximal inhibitory concentration in the acid ceramidase assay: 4.1 nM
Beside the measured number, compound 4's estimate is 1.3-fold (0.13 log units) above it; low and high end bracket the measured number.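

Ethyl in place of phenyl gives, in the acid ceramidase assay, a 2.0-fold higher number from compound 1 to compound 4 (0.29 log units; within the scatter), and this step does not differ from the one measured on the other core: the same change on two cores in the acid ceramidase assay, a 2.6-fold higher number (0.42 log units; beyond the scatter) from compound 2 to compound 3 and a 2.0-fold higher number (0.29 log units; within the scatter) from compound 1 to compound 4, 1.4-fold (0.13 log units) apart, within the scatter of two such steps. The change therefore carries across these two cores with no detectable dependence on the core, but two pairs show nothing about any further core or any other chain. The step cannot be read in a physicochemical assay for metabolic stability, read by HPLC, at pH 4.5, tested at 10 uM (on this read-out lower numbers stand for a shorter-lived compound and higher numbers for a longer-lived compound), where each value is a limit of the assay and not a number: the limit of > 2 h in the physicochemical assay, at which 2 of the 2 values shown sit. In the physicochemical assay compound 1 gives > 2 h, which is a limit of the assay. In the physicochemical assay compound 4 gives > 2 h, which is also a limit of the assay.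

On these data alone, whether the half-lives of compound 1 and compound 4 differ beyond that limit stays open. Also open, as far as these compounds go, is how a longer chain, or a chain ending in an amine or a carboxylic acid, would behave on either core.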